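Working notes: bromo in place of fluoro

This account rests on a few compounds, and the source may have more. Where it says the series, first, only, none or still open, it means among the compounds named here.

In a functional assay on KG-1 cells (Homo sapiens) for cytotoxicity, read by luminescence and CellTiter-Glo, with a stated time of 3 days (a lower number here means a stronger inhibitor, a higher number a weaker inhibitor), compound 3 (`N#Cc1ccc(NC(=O)c2ccc(F)cc2O)cc1`) gives 3150 nM. Compound 1 (`N#Cc1ccc(NC(=O)c2ccc(Cl)cc2O)cc1`) gives 1920 nM, within the scatter of compound 3. Compound 2 (`O=C(Nc1ccc(C(F)(F)F)cc1)c1ccc(Br)cc1O`) gives 340 nM, and its gap to compound 3 lies beyond the scatter, with compound 2 holding the lower number.

The next compound to be measured is compound 4 (`N#Cc1ccc(NC(=O)c2ccc(Br)cc2O)cc1`). Its change from compound 3 is bromo in place of fluoro on an aromatic carbon, meta to a hydroxy group and para to a large group: bromo in place of fluoro on an aromatic carbon.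

Going by the values given here, only one measured step touches this place: a 1.6-fold higher number from compound 1 to compound 3 (0.22 log units; within the scatter), with fluoro in place of chloro. That step stays within the scatter, so swapping these halogens has so far moved the number very little. Among the compounds with values here, compound 2 also carries bromo, but no measured step isolates that group, so its value gives only a weak hint towards a lower number.

A modest shift towards a lower number is therefore expected, about as large as the scatter, and the estimated step is a 2.0-fold lower number from compound 3 to compound 4 (0.29 log units; within the scatter). For compound 4 the estimate is 1600 nM, with an expected range from 750 nM to 3300 nM.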

Compound 4, half-maximal inhibitory concentration: 1450 nM
Compound 4: the middle estimate sits 1.1-fold (0.04 log units) above what was measured; the measured number falls inside the stated range.
By their numbers in this assay, from the lowest: compound 2; then compounds 4, 1 and 3 (each within the scatter of the next, the first and the last beyond it).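

Going by these compounds alone, at this position the halogen now shows a readable effect in this assay: a 2.2-fold lower number from compound 3 to compound 4 (0.34 log units; beyond the scatter) is the first step here to lie beyond the scatter, whereas a 1.3-fold lower number from compound 1 to compound 4 (0.12 log units; within the scatter) stays within it, so chloro and bromo cannot be ordered and only fluoro and bromo stand apart. With bromo held constant, a 4.3-fold higher number from compound 2 to compound 4 (0.63 log units; beyond the scatter) comes with cyano in place of trifluoromethyl on an aromatic carbon, so bromo alone does not account for the low number of compound 2, and this second place carries a step of its own. Nothing measured here bears on why these numbers move.

Whether bromo in place of fluoro gives a similar step when trifluoromethyl replaces cyano stays open, as compound 2 has no fluoro or chloro partner among the compounds shown. On these data alone, only halogens appear at this position in these compounds, so how an amine or a methoxy group would read there, and whether the trend from fluoro to bromo extends beyond halogens, also remains open.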